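This account rests on a few compounds, and the source may have more. Where it says the series, first, only, none or still open, it means among the compounds named here.

Of the compounds shown here, two have been measured in a functional assay on CHO cells for agonist activity at 5-hydroxytryptamine receptor 4 (Homo sapiens), read by a luciferase reporter and cAMP accumulation, with a stated time of 4 h; a lower number here means a smaller maximal response, a higher number a larger maximal response. Compound 1 `COCCCN1CCC(O)(CNC(=O)c2nc(C(C)C)n3ccccc23)CC1` gives 41% in this assay. Compound 2 `CC(C)c1nc(-c2nnc(C3CCN(C4CCC4)CC3)o2)c2ccccn12` gives 55% in this assay, the higher of the two numbers, and its gap to compound 1 lies beyond the usual scatter. Within the data shown here, no pair of measured compounds differs in only one place, so no single structural change has yet been tied to a change in the number. Compound 3 `CC(C)c1nc(-c2nnc(C3CCN(C(C)C)CC3)o2)c2ccccn12` has not been measured. It differs from compound 2 in one place: isopropyl in place of cyclobutyl on an amine nitrogen in a ring. Both groups are small pieces of carbon only, and neither brings a donor or an acceptor, so the step in this assay from compound 2 to compound 3 is expected to be small, most likely within the scatter, with a slight drop as the more probable direction: a number 5 percentage points lower from compound 2 to compound 3 (within the scatter). Compound 3 is therefore expected to reach about 50%, within a range from 30% to 70%.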

Compound 3, largest response reached (Emax), in percent of the reference or control that the assay uses: 65%
The estimate for compound 3 lay 15 percentage points below the measured number; the measured number falls inside the stated range.
By their numbers in this assay, from the lowest: compound 1; then compounds 2 and 3 (each within the scatter of the next).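

In this assay, among these compounds, the exchange of cyclobutyl for isopropyl on the amine nitrogen in a ring gives a number 10 percentage points higher from compound 2 to compound 3 (within the scatter) and this is the first single change that can be read. At this position, then, the four-membered carbon ring is not needed to keep the maximal response, since a carbon group with no ring serves within the scatter. Nothing measured here explains how the two groups come to read alike.

Going by these compounds, both groups are made of carbon only, so it stays open how this nitrogen behaves with a methyl group, a benzyl group or a hydroxyethyl chain. Also open, on these data alone, is whether the isopropyl on the shared core can give way to a cyclopropyl or a methyl group.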